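Methoxy for cyano on the aryl of compound 1

The compounds below may be only part of what the source reports. "The series", "measured", "known", "first", "only" and "open" are said of these compounds alone.

Compound 1 `Cn1cnnc1SCC(=O)N/N=c1/scc(-c2ccc(C#N)cc2)n1-c1ccccc1` carries a 4-methyl-4H-1,2,4-triazol-3-yl on sulfur. In an ADME assay on NIH3T3 cells (Mus musculus) for cytotoxicity, read by MTT assay, with a stated time of 24 h (on this read-out higher numbers stand for weaker inhibition and lower numbers for stronger inhibition), compound 1 gives 153 ug/mL. Compound 2 `Cn1nnnc1SCC(=O)N/N=c1/scc(-c2ccc(C#N)cc2)n1-c1ccccc1` gives 213 ug/mL in this assay, a step that stays within the scatter a 1.4-fold higher number from compound 1 to compound 2 (0.14 log units; within the scatter). Compound 3 `N#Cc1ccc(-c2cs/c(=N/NC(=O)CSc3nnnn3-c3ccccc3)n2-c2ccccc2)cc1` gives 453 ug/mL in this assay, a modest step beyond the scatter a 3.0-fold higher number from compound 1 to compound 3 (0.47 log units; beyond the scatter), and from compound 2 the step is also modest a 2.1-fold higher number from compound 2 to compound 3 (0.33 log units; beyond the scatter). All three measured steps alter the heterocycle on sulfur or its substituent on the aromatic nitrogen.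

Compound 4 `COc1ccc(-c2cs/c(=N/NC(=O)CSc3nncn3C)n2-c2ccccc2)cc1` differs from compound 1 elsewhere: methoxy in place of cyano on an aromatic carbon. Among the compounds with values here, no measured step touches this position, so nothing speaks to the size or direction of the change; the heterocycle changes gave at most modest steps, and the group swap here is comparable in heavy-atom count. The expected step for this assay is therefore none beyond the scatter, no change at the digits printed from compound 1 to compound 4 (within the scatter). Compound 4 is estimated at 153 ug/mL, with a range from 60 ug/mL to 400 ug/mL.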

Compound 4, half-maximal inhibitory concentration: 167 ug/mL
Compound 4: middle estimate off by 1.1-fold (0.04 log units), on the low side, within the range that was stated.
By their numbers in this assay, from the lowest: compounds 1, 4 and 2 (each within the scatter of the next); then compound 3.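

In this assay, within the data shown here, the change from 4-cyanophenyl to 4-methoxyphenyl gives a 1.1-fold higher number from compound 1 to compound 4 (0.04 log units; within the scatter) and provides the first measured read at this aryl position, as the earlier steps altered only the heterocycle on sulfur or its substituent on the aromatic nitrogen. With the 4-methyl-4H-1,2,4-triazol-3-yl group held constant, this read-out does not separate nitrile from methoxy at this position. Nothing shown bears on why the two groups read alike.

This single pair leaves open whether the same swap would also stay within the scatter on the tetrazole groups of compound 2 and compound 3. Going by these compounds, how an amine, a carboxylic acid or a longer alkoxy chain on this aromatic carbon would read also remains open.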